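Adding a Methyl to the Amine Nitrogen of Compound 1

The source may report more compounds than this note shows. Statements on the series, on what has been measured and on what is new or still open speak of the compounds shown alone.

Compound 1 `Cc1ccccc1-c1nnc(NNC(C)C)s1` was tested in a functional assay on the whole organism with Mus musculus as the target, with a stated time of 1 h (a lower number here means that less compound is needed, a higher number that more compound is needed for the effect), where compound 1 gives 54 mg/kg. Among the compounds with values here, of the two numbers measured this is the higher, but its only neighbour, compound 2 `CC(C)NNc1nnc(-c2ccccc2-c2ccccc2)s1`, gives 44 mg/kg in this assay, and the step of a 1.2-fold lower number from compound 1 to compound 2 (0.09 log units; within the scatter) lies within the scatter. Within the data shown here, that step exchanges methyl for phenyl on an aromatic carbon and is the only measured step available.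

Compound 3 `Cc1ccccc1-c1nnc(NN(C)C(C)C)s1` is not yet measured. It differs from compound 1 by methyl in place of hydrogen on an amine nitrogen. Among the measured compounds shown here, no measured step touches the amine nitrogen, so nothing among the measured compounds bears directly on this change; the single step, from compound 1 to compound 2, concerns a different position and was itself within the scatter. Compound 3 is therefore expected to sit close to compound 1, with the step of no change at the digits printed from compound 1 to compound 3 (within the scatter) expected to stay within the scatter. The estimate for compound 3 is 54 mg/kg, with a range from 27 mg/kg to 110 mg/kg.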

Compound 3, dose for half-maximal effect: > 100 mg/kg
Compound 3 gave a limit, no number; the forecaster's own chance of this, stated with the estimate: 5%; at least 1.8-fold (0.26 log units) between middle value and limit.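

This is the only step shown that touches the amine nitrogen, and methyl in place of hydrogen there gives an at least 1.8-fold higher number from compound 1 to compound 3 (0.26 log units; that floor lies within the scatter). Compound 3 gives a limit of the assay and not a number: the limit of > 100 mg/kg in this assay, at which 1 of the 3 values shown sits. The earlier compounds shown here said nothing about this nitrogen, whereas this result gives the change a direction, towards more compound being needed in this assay, though only as a floor that does not by itself clear the scatter.

From the compounds shown here alone, how large the true step is stays open, and so does whether the same methyl would act alike on compound 2, which carries phenyl in place of the methyl on the aromatic carbon. Also open, going by these compounds, is how an ethyl group or an acetyl group on this amine nitrogen would compare with hydrogen and methyl.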